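Oxygen-Linked Pyrimidine Replaces Thio-Benzimidazole in a Ketone Series

This account rests on a few compounds, and the source may have more. Where it says the series, first, only, none or still open, it means among the compounds named here.

Three compounds share one core and differ only in the group on a saturated chain carbon bound to a carbonyl carbon. In a functional assay on Jurkat cells (Homo sapiens) for inhibition (a lower number here means a stronger inhibitor, a higher number a weaker inhibitor), compound 1 `COC(=O)c1cc(OCC(=O)[C@H](CC(=O)O)NC(=O)[C@@H](NC(=O)COc2cccc3ccccc23)C(C)C)no1` gives 71000 nM. Compound 2 `CC(C)[C@H](NC(=O)COc1cccc2ccccc12)C(=O)N[C@@H](CC(=O)O)C(=O)CSc1nncn1C` reaches only a limit of this assay, > 200000 nM. Compound 3 `CC(C)[C@H](NC(=O)COc1cccc2ccccc12)C(=O)N[C@@H](CC(=O)O)C(=O)CSc1nc2ccccc2[nH]1` likewise reaches only a limit, > 200000 nM. The measured steps are an at least 2.8-fold higher number from compound 1 to compound 2 (0.44 log units; beyond the scatter) and an at least 2.8-fold higher number from compound 1 to compound 3 (0.44 log units; beyond the scatter), while a step that the two limits leave unreadable from compound 2 to compound 3 because of the limit of > 200000 nM in this assay, at which 2 of the 3 values shown sit.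

Compound 4 `CC(C)[C@H](NC(=O)COc1cccc2ccccc12)C(=O)N[C@@H](CC(=O)O)C(=O)COc1ccnc(C(F)(F)F)n1` differs from compound 3 by (2-(trifluoromethyl)pyrimidin-4-yl)oxy in place of (1H-benzimidazol-2-yl)sulfanyl on a saturated chain carbon bound to a carbonyl carbon. Both earlier steps away from the (5-(methoxycarbonyl)-1,2-oxazol-3-yl)oxy group weakened inhibition. Compound 3 itself stands only at a limit of this assay. Compound 4 may come back toward a measurable number because compound 1 gives 71000 nM with a ring-bearing oxy group at the same place. Compound 4 is therefore expected to give about 100000 nM, within 30000 nM to 300000 nM. The expected step is an at least 2.0-fold lower number from compound 3 to compound 4 (0.30 log units; that floor lies within the scatter), though a limit remains possible.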

Compound 4, half-maximal inhibitory concentration: 37000 nM
Compound 4: middle estimate off by 2.7-fold (0.43 log units), on the high side; measured number inside the range.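

In this assay, moving from a sulfur-linked group to (2-(trifluoromethyl)pyrimidin-4-yl)oxy at this position gives an at least 5.4-fold lower number from compound 3 to compound 4 (0.73 log units; beyond the scatter) and also an at least 5.4-fold lower number from compound 2 to compound 4 (0.73 log units; beyond the scatter). Changing the ring on the oxygen, with 2-(trifluoromethyl)pyrimidin-4-yl in place of 5-(methoxycarbonyl)-1,2-oxazol-3-yl, gives a 1.9-fold lower number from compound 1 to compound 4 (0.28 log units; within the scatter), so compound 1 and compound 4 cannot be told apart, and this position accepts two different rings on oxygen. For the compounds shown here, in all four compounds the oxy groups give measurable numbers and the sulfanyl groups reach a limit, yet no pair carries the same ring on oxygen and on sulfur, so the linking atom cannot be separated from the ring.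

The gap between compound 2 and compound 3 cannot be read, because both stop at the same limit: the limit of > 200000 nM in this assay, at which 2 of the 4 values shown sit. As far as these compounds go, whether an amine in place of the linking oxygen of compound 4 would keep a measurable number also stays open.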